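Benzimidazole amide series: ortho-methoxy in place of para-fluoro

A few compounds are considered here, and "the series" means these few. Any claim that something is new, unique, unknown or untested is made for them only; others in the source may bear on it.

Working notes on the amide series around the shared core of compound 1 `O=C(Nc1ccc(Cl)c(-c2nc3ccccc3[nH]2)c1)c1ccc(F)cc1`. In a functional assay on Shh Light II cells for inhibition of Sonic hedgehog protein (Mus musculus), read by reporter gene assay, with a stated time of 48 h, in the presence of a further agent that is not named here (a lower number here means a stronger inhibitor, a higher number a weaker inhibitor), compound 1 gives 251 nM. Going by the values given here, compound 2 `O=C(Nc1ccc(Cl)c(-c2nc3ccccc3[nH]2)c1)c1cccc(C(F)(F)F)c1` carries a trifluoromethylphenyl on the carbonyl carbon and gives 119 nM in this assay; of the two numbers so far, compound 1 is the higher and compound 2 the lower, and the gap between them lies beyond the usual scatter. Compound 3 `CCOc1cc(C(=O)Nc2ccc(Cl)c(-c3cc4ccccc4[nH]3)c2)cc(OC)c1OC`, which has a different core and a more heavily substituted aryl on the carbonyl, is reported in this assay as "not active" (no number reported), with no number given, so it offers no scale for the effect of alkoxy groups on the aryl.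

Compound 4 `COc1ccccc1C(=O)Nc1ccc(Cl)c(-c2nc3ccccc3[nH]2)c1` has not yet been measured in this assay. Its structure differs from compound 1 as follows: 2-methoxyphenyl in place of 4-fluorophenyl on a carbonyl carbon. Among the compounds with values here, no measured pair in the set shows this change directly, so the expected size of the step rests on the two numbers for compound 1 and compound 2 alone, which show only that aryl substitution moves the value by a modest amount. A small weakening is expected for compound 4, with an estimated step from compound 1 given by a 1.8-fold higher number from compound 1 to compound 4 (0.25 log units; within the scatter). Compound 4 is therefore estimated at 450 nM, with a plausible range from 130 nM to 1600 nM in this assay.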

Compound 4, half-maximal inhibitory concentration: 876 nM
For compound 4 the middle estimate is 1.9-fold (0.29 log units) below the measured one; measured number inside the range.
By their numbers in this assay, from the lowest: compound 2; then compound 1; then compound 4.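

In this assay, going by these compounds alone, 2-methoxyphenyl in place of 4-fluorophenyl on a carbonyl carbon gives a 3.5-fold higher number from compound 1 to compound 4 (0.54 log units; beyond the scatter), the first step that can be read at a single place, and it lies beyond the usual scatter. Within the data shown here, it shows that the aryl on this carbonyl carbon is not a freely exchangeable part of the shared core of compound 1: this swap, in which the entering group carries one hydrogen-bond acceptor and the leaving group none, moves the number upward by a modest but real amount, whereas the earlier numbers gave no single-place step at all. No measurement in hand bears on the reason for this rise.

One step cannot separate the effect of replacing fluorine with a methoxy group from the effect of where each group sits on the phenyl ring, so the change remains a single observation rather than a trend. The compounds shown also leave open how this carbonyl position would respond to a hydroxy group, an amine or a carboxylic acid on the phenyl ring, or to a saturated alkyl chain in place of the ring.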